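A chloro on the benzylsulfanyl arm of two related cores

The compounds below may be only part of what the source reports. "The series", "measured", "known", "first", "only" and "open" are said of these compounds alone.

The measured compounds:
compound 1, `COc1ccc(C2N=C(SCc3ccccc3)NC(C)=C2C(=O)Nc2ccc(Br)cc2)cc1`, gives 2.6% in a functional assay on the whole organism (artery, strain albino) with Rattus norvegicus as the target, with a stated time of 30 min, at a dose of 10 mg/kg by the oral route; a higher number here means more inhibition at the dose given (going by the name of the read-out), a lower number less inhibition;
compound 2, `COc1ccc(C2N=C(SCc3ccc(Cl)cc3)NC(C)=C2C(=O)Nc2ccc(Br)cc2)cc1`, gives 7.2%;
compound 3, `CC1=C(C(=O)Nc2ccc([N+](=O)[O-])cc2)C(c2cccc([N+](=O)[O-])c2)N=C(SCc2ccccc2)N1`, gives 4.1%.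

Compound 1 and compound 2 differ by chloro in place of hydrogen on an aromatic carbon, and that change made a step of a number 4.6 percentage points higher from compound 1 to compound 2 (within the scatter). Compound 3 carries a different core; the difference between the two cores is not broken down here. Compound 4, `CC1=C(C(=O)Nc2ccc([N+](=O)[O-])cc2)C(c2cccc([N+](=O)[O-])c2)N=C(SCc2ccccc2Cl)N1`, stands to compound 3 as compound 2 stands to compound 1, through (chloro in place of hydrogen on an aromatic carbon). This is the same kind of change, not the same: in compound 2 the chloro sits para to a large group, in compound 4 ortho to a large group. The step from compound 3 to compound 4 is expected to be small, about a number 2.9 percentage points higher from compound 3 to compound 4 (within the scatter), because the earlier step of a number 4.6 percentage points higher from compound 1 to compound 2 (within the scatter) lay within the scatter and compound 3 begins from 4.1%. Compound 4 is therefore estimated at 7%, between -5% and 19%.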

Compound 4, a percentage reported as inhibition, in the whole organism at one dose (the size of the read-out at that dose, not a potency): 3.6%
Compound 4: the middle estimate sits 3.4 percentage points above what was measured; measured number inside the range.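

In this assay, adding the chloro to the second core gave a step of a number 0.5 percentage points lower from compound 3 to compound 4 (within the scatter). Set beside the earlier step, this gives no sign that the change behaves differently on the two cores: the same change on two cores in this assay, a number 4.6 percentage points higher (within the scatter) from compound 1 to compound 2 and a number 0.5 percentage points lower (within the scatter) from compound 3 to compound 4, 5.1 percentage points apart, within the scatter of two such steps. It does not show that the change carries over either: neither step stands clear of the scatter, and the chloro in compound 4 sits ortho to a large group, which is not its place in compound 2.

From the compounds shown here alone, it remains open what the chloro would do at one and the same place on both cores. The compounds shown also leave open what an amine or a methoxy on the benzyl ring, or a longer chain in place of the benzyl, would give.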